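The source may hold more compounds than are shown below. What is called first, only, known or untested is meant among the compounds shown, and "the series" means these compounds.

Two pairs of compounds share one small exchange on an outer ring. Compound 1 `Cc1ccc(Nc2ccc3c(c2)/C(=C\C2CCCCC2)C(=O)N3)cc1` carries a methyl on an aromatic carbon; compound 2 `O=C1Nc2ccc(Nc3ccc(Cl)cc3)cc2/C1=C\C1CCCCC1` carries a chloro at that same place, the change being (chloro in place of methyl on an aromatic carbon). In a functional assay on A549 cells (Homo sapiens) for antiproliferative activity, read by MTT assay, with a stated time of 48 h (a higher number here means a weaker inhibitor, a lower number a stronger inhibitor), compound 1 gives 28200 nM, while compound 2 gives 2400 nM, so that the step of a 12-fold lower number from compound 1 to compound 2 (1.07 log units; beyond the scatter) is a large gain in inhibition for a change of a single heavy atom.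

Compound 3 `Cc1ccc(Nc2ccc3c(c2)C(CCC(C)C)C(=O)N3)cc1` keeps the methyl-bearing outer ring of compound 1 but sits on a different core; how the two cores differ is not broken down here. In this assay compound 3 gives 6600 nM, a number that lies between those of compound 1 and compound 2.

Compound 4 `CC(C)CCC1C(=O)Nc2ccc(Nc3ccc(Cl)cc3)cc21` is to compound 3 what compound 2 is to compound 1: the change chloro in place of methyl on an aromatic carbon is the same change, at the same kind of place on the same kind of ring. Compound 4 has not yet been measured in this assay. For the measured compounds named here, because the single earlier instance of this change gave a 12-fold lower number from compound 1 to compound 2 (1.07 log units; beyond the scatter), the expectation is that compound 4 will also show a lower number than compound 3, though with a different core the size of the step is uncertain and is estimated somewhat smaller, at a 4.4-fold lower number from compound 3 to compound 4 (0.64 log units; beyond the scatter). On that basis compound 4 is expected to give about 1500 nM, most likely between 500 nM and 5000 nM.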

Compound 4, half-maximal inhibitory concentration: 2000 nM
For compound 4 the middle estimate is 1.3-fold (0.12 log units) below the measured one; the range from low to high includes it.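

In this assay, putting chloro in place of methyl lowers the number on both cores, so the direction of the change carries over, here with a 3.3-fold lower number from compound 3 to compound 4 (0.52 log units; beyond the scatter). The size of the step does not carry over unchanged, and the two steps differ by more than the usual scatter of such measurements: the same change on two cores in this assay, a 12-fold lower number (1.07 log units; beyond the scatter) from compound 1 to compound 2 and a 3.3-fold lower number (0.52 log units; beyond the scatter) from compound 3 to compound 4, 3.6-fold (0.55 log units) apart, beyond the scatter of two such steps. These two pairs show that the gain from 4-methylphenyl to 4-chlorophenyl is not a fixed amount in this series, but they do not show which feature of the cores sets its size or how the change would behave on a further core.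

The compounds shown carry only methyl or chloro at this place on the outer ring, so it remains open whether fluoro, methoxy or trifluoromethyl there would lower the number on either core. As far as these compounds go, it also remains open whether the step from methyl to chloro would keep its size with a longer chain on the core of compound 3.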